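The source may report more compounds than this note shows. Statements on the series, on what has been measured and on what is new or still open speak of the compounds shown alone.

Measured so far:

Compound 2, `C=CCOc1ccc(/C=C/C(=O)c2ccccc2NC(=O)NS(=O)(=O)c2ccc(C)cc2)cc1`, gives 6.11 ug/mL.
Compound 1, `COc1cccc(/C=C/C(=O)c2ccccc2NC(=O)NS(=O)(=O)c2ccc(C)cc2)c1`, gives 23.2 ug/mL.

Both numbers come from an ADME assay on the whole organism for cytotoxicity, with Artemia salina as the target, with a stated time of 24 h; a lower number here means that less compound is needed, a higher number that more compound is needed for the effect. Among the measured compounds shown here, compound 2 stands at the lowest number of the two, and the only measured step, a 3.8-fold lower number from compound 1 to compound 2 (0.58 log units; beyond the scatter), shows that swapping the group on that chain carbon can move the number by a modest amount.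

Compound 3, `Cc1ccc(S(=O)(=O)NC(=O)Nc2ccccc2C(=O)/C=C/C=C/c2ccccc2)cc1`, is the next candidate. It differs from compound 2 in one place: 2-phenylethenyl in place of 4-(allyloxy)phenyl on a double-bonded chain carbon bound to a double-bonded chain carbon. For the measured compounds named here, no measured step covers this exact change; the one step in hand only shows that exchanging one aromatic group for another at this position shifts the number modestly rather than strongly. Since the incoming group carries a further double bond and no acceptor, the result could land on either side of compound 2, so the expectation is a step of roughly the same size as the one seen, most likely back toward the number of compound 1.

Compound 3 is therefore expected to show a 1.6-fold higher number from compound 2 to compound 3 (0.21 log units; within the scatter), that is, an estimated 10 ug/mL with a likely range from 3.5 ug/mL to 28 ug/mL.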

Compound 3, concentration for half-maximal effect: 18.2 ug/mL
The estimate for compound 3 lay 1.8-fold (0.26 log units) below the measured number; the range from low to high includes it.
By their numbers in this assay, from the lowest: compound 2; then compounds 3 and 1 (each within the scatter of the next).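

In this assay, replacing 4-(allyloxy)phenyl with 2-phenylethenyl gives a 3.0-fold higher number from compound 2 to compound 3 (0.47 log units; beyond the scatter), a second sign that the group at this place on the chain can move the number beyond the scatter. The other comparison gives a 1.3-fold lower number from compound 1 to compound 3 (0.11 log units; within the scatter), so 2-phenylethenyl and 3-methoxyphenyl cannot be told apart in this test, even though one of these groups carries an oxygen and the other does not, while compound 2 is separated from both by steps beyond the scatter. Nothing available here explains these differences.

The compounds shown do not reveal whether the lower number of compound 2 depends on the allyl part of its 4-(allyloxy)phenyl group or on the oxygen that joins this part to the ring, since no compound separates the two. They also leave open how this position would respond to a very different group, such as an amine or a carboxylic acid on the phenyl ring, or a longer chain in place of the allyl group.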